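The compounds below may be only part of what the source reports. "The series", "measured", "known", "first", "only" and "open" are said of these compounds alone.

Three compounds share one core and differ only in the group attached to the saturated six-membered ring. Compound 2 `c1ccc(CNCC2CCN(CCCc3c[nH]c4ccc(-n5cnnc5)cc34)CC2)cc1` carries a benzylamino group on a chain carbon there; in an assay on CHO cells for displacement of a labelled ligand from 5-hydroxytryptamine receptor 1D (Homo sapiens) (a lower number here means a stronger inhibitor, a higher number a weaker inhibitor), compound 2 gives 1.6 nM. Compound 1 `CN(CC1CCN(CCCc2c[nH]c3ccc(-n4cnnc4)cc23)CC1)C(=O)Nc1ccccc1` gives 5.9 nM, and compound 3 `CC(=O)Nc1ccc([C@H](C)NCC2CCN(CCCc3c[nH]c4ccc(-n5cnnc5)cc34)CC2)cc1` gives 0.6 nM. So compound 2 stands second highest of the three numbers: the step of a 3.7-fold lower number from compound 1 to compound 2 (0.57 log units; beyond the scatter) and the step of a 2.7-fold lower number from compound 2 to compound 3 (0.43 log units; beyond the scatter) are both modest, yet each lies beyond the scatter.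

Compound 4 `c1cc(CNC2CCN(CCCc3c[nH]c4ccc(-n5cnnc5)cc34)CC2)co1` changes the same region again: ((furan-3-yl)methyl)amino in place of (benzylamino)methyl on a saturated ring carbon. Neither measured step covers this exact change, which both shortens the link to the ring and swaps the aromatic ring; the two steps that touch this region each moved the number by only a modest amount. A change of similar or smaller size is therefore expected, in either direction, and compound 4 is estimated at 4 nM, within 1 nM to 15 nM, which means an expected step of a 2.5-fold higher number from compound 2 to compound 4 (0.40 log units; beyond the scatter).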

Compound 4, half-maximal inhibitory concentration: 4.5 nM
For compound 4 the middle estimate is 1.1-fold (0.05 log units) below the measured one, within the range that was stated.
By their numbers in this assay, from the lowest: compound 3; then compound 2; then compounds 4 and 1 (each within the scatter of the next).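

In this assay, the step of a 2.8-fold higher number from compound 2 to compound 4 (0.45 log units; beyond the scatter) is modest but beyond the scatter, so this position still gives a low number when the substituent is altered in two ways at once. The amine now sits directly on the saturated ring carbon, without the methyl link, and a five-membered aromatic ring with one hetero atom replaces the six-membered aromatic ring of carbon only. Because both changes arrive together, this step cannot show how much each contributes, and nothing measured here explains the rise in the number.

On these data alone, it remains open whether benzylamino placed directly on the ring carbon, or a ((furan-3-yl)methyl)aminomethyl group that keeps the link, would separate the two effects. As far as these compounds go, it is also open whether a pyridine or thiophene ring would give a similar number.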